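Amide replacements for the imide arm of compound 1

The source may report more compounds than this note shows. Statements on the series, on what has been measured and on what is new or still open speak of the compounds shown alone.

Compound 1 `CN1[C@@H]2c3[nH]c4ccccc4c3C[C@H]1[C@H](C#N)N1[C@@H](CN3C(=O)c4ccccc4C3=O)c3[nH]c4ccccc4c3C[C@@H]21` gives 610 nM in a functional assay on MCF7 cells (Homo sapiens) for cytotoxicity, read by MTT assay, with a stated time of 72 h (on this read-out lower numbers stand for stronger inhibition and higher numbers for weaker inhibition), the highest number among the three measured compounds. Compound 2 `CCc1ccc(C(=O)NC[C@H]2c3[nH]c4ccccc4c3C[C@H]3[C@H]4c5[nH]c6ccccc6c5C[C@@H]([C@H](C#N)N23)N4C)cc1` gives 170 nM in this assay, and compound 3 `CN1[C@@H]2c3[nH]c4ccccc4c3C[C@H]1[C@H](C#N)N1[C@@H](CNC(=O)c3ccc4ccccc4n3)c3[nH]c4ccccc4c3C[C@@H]21` gives 150 nM. Among the measured compounds shown here, the one step away from compound 1 that is measured is a 3.6-fold lower number from compound 1 to compound 2 (0.55 log units; beyond the scatter); between the two amides, a 1.1-fold lower number from compound 2 to compound 3 (0.05 log units; within the scatter), so the two aryl groups on the carbonyl are not separated on these numbers.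

Compound 4 `CN1[C@@H]2c3[nH]c4ccccc4c3C[C@H]1[C@H](C#N)N1[C@@H](CNC(=O)c3cc4ccccc4s3)c3[nH]c4ccccc4c3C[C@@H]21` carries the same chain as compounds 2 and 3 but a different aryl group on the carbonyl. Against compound 1 the change is a group of 12 heavy atoms (9 carbon, 1 nitrogen, 1 oxygen, 1 sulfur; one five-membered aromatic ring with 1 hetero atom, one six-membered aromatic ring of carbon only) in place of a group of 11 heavy atoms (8 carbon, 1 nitrogen, 2 oxygen; one five-membered non-aromatic ring with 1 hetero atom, one six-membered aromatic ring of carbon only), on a saturated chain carbon bound to a saturated ring carbon.

For the measured compounds named here, the step that bears on this change is the one from compound 1 to compound 2, which replaced the same departing group with an aryl carboxamide and lowered the number beyond the scatter. Compound 3 shows the same pattern in its value relative to compound 1. For compound 4 the step is expected to be a 3.8-fold lower number from compound 1 to compound 4 (0.58 log units; beyond the scatter), in the lowering direction. The estimate for compound 4 in this assay is 160 nM, expected to fall between 70 nM and 400 nM.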

Compound 4, half-maximal inhibitory concentration: 3180 nM
The estimate for compound 4 lay 20-fold (1.30 log units) below the measured number; the whole stated range lies below it.
By their numbers in this assay, from the lowest: compounds 3 and 2 (each within the scatter of the next); then compound 1; then compound 4.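

In this assay, the amide link on the chain does not by itself carry a lower number than the imide arm: 1-benzothiophen-2-yl gives a 5.2-fold higher number from compound 1 to compound 4 (0.72 log units; beyond the scatter), opposite in direction to a 3.6-fold lower number from compound 1 to compound 2 (0.55 log units; beyond the scatter), so compound 4 goes against the pattern that compounds 2 and 3 suggested. The aryl group on the carbonyl, which compounds 2 and 3 left unseparated, therefore matters at this position, with 1-benzothiophen-2-yl in place of quinolin-2-yl giving a 21-fold higher number from compound 3 to compound 4 (1.33 log units; beyond the scatter) and in place of 4-ethylphenyl giving a 19-fold higher number from compound 2 to compound 4 (1.27 log units; beyond the scatter). Nothing available on these compounds explains this reversal.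

From the compounds shown here alone, whether the higher number follows the sulfur atom or the five-membered aromatic ring stays open, and a 1-benzofuran-2-yl or naphthalen-2-yl group on the same carbonyl would bear on that question. Also open, going by these compounds, is whether the amide hydrogen contributes to the values in this assay, which a methyl group on the amide nitrogen would test for each of these aryl groups.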